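Trifluoromethyl replacing a hydroxylated chain in cytotoxicity

The source may report more compounds than this note shows. Statements on the series, on what has been measured and on what is new or still open speak of the compounds shown alone.

Compound 1 `CS(=O)(=O)CCCn1c(Cn2cc(S(C)(=O)=O)c3ccccc32)nc2cc(Cl)ccc21` gives > 100000 nM in an ADME assay on HEp-2 cells (Homo sapiens) for cytotoxicity, with a stated time of 4 days (on this read-out higher numbers stand for lower toxicity in this test and lower numbers for higher toxicity in this test), a limit.
Compound 2 `CS(=O)(=O)c1nn(Cc2nc3cc(Cl)ccc3n2CCCCO)c2cnccc12` gives > 100000 nM in this assay, a limit.
Compound 3 `CC(C)(O)CCCn1c(Cn2nc(S(C)(=O)=O)c3ccncc32)nc2cc(Cl)ccc21` gives > 100000 nM in this assay, a limit.

Compound 3 therefore stands only at a limit of this assay, as do the other two compounds. Among the compounds with values here, the one step that can be read between measured compounds, a step that the two limits leave unreadable from compound 2 to compound 3, is left unreadable by the two limits, so no measured change offers a size to carry forward. What is known is summed up by the limit of > 100000 nM in this assay, at which 3 of the 3 values shown sit.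

Compound 4 `CS(=O)(=O)c1nn(Cc2nc3cc(Cl)ccc3n2CCC(F)(F)F)c2cnccc12` differs from compound 3 by trifluoromethyl in place of 2-hydroxy-2-methylpropyl on a saturated chain carbon, two bonds along the chain from an aromatic nitrogen. Within the data shown here, no measured step bears directly on this change, and every value in hand is a limit. With compound 3 resting at the limit, the estimated step of a number no higher from compound 3 to compound 4 (the limit leaves the size open) is expected to be none beyond the scatter. Compound 4 is thus expected to give about 100000 nM in this assay, within a range from 30000 nM to 300000 nM, most probably again reported only as a limit.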

Compound 4, half-maximal cytotoxic concentration: > 100000 nM
Compound 4 ended at the assay's limit (the forecaster's own chance of this, stated with the estimate: 80%); the middle value lies on the limit itself.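

Compound 4 also rests at a limit, so the steps to it from compound 2 and compound 3 cannot be read. All the data reduce to one statement: the limit of > 100000 nM in this assay, at which 4 of the 4 values shown sit.

The compounds shown leave open whether any of these chain changes alters the read-out of this assay at all.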